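Isobutyl in Place of sec-Butyl on the Carbamoyl Nitrogen

A few compounds are considered here, and "the series" means these few. Any claim that something is new, unique, unknown or untested is made for them only; others in the source may bear on it.

Compound 1, `O=C(NCCCCc1ccccc1)n1c(=O)oc2cc(C3CCCCC3)ccc21`, in an assay on HEK293 cells for inhibition of acid ceramidase (Homo sapiens), read by fluorescence, with stated times of 10 min and 3 h; on this read-out higher numbers stand for weaker inhibition and lower numbers for stronger inhibition: 89 nM
Compound 2, `CCOCCNC(=O)n1c(=O)oc2cc(C3CCN(C)CC3)ccc21`: 1050 nM
Compound 3, `CCC(C)NC(=O)n1c(=O)oc2cc(C3CCN(C)CC3)ccc21`: 2100 nM

Compound 3 stands at the top end of these three numbers. Within the data shown here, its nearest neighbour is compound 2: the step of a 2.0-fold higher number from compound 2 to compound 3 (0.30 log units; within the scatter) is the only single-point comparison among the measured compounds, and it does not reach beyond the scatter, so the two cannot be told apart. Compound 1 differs from compound 3 in two places and is not a single step; the value of compound 1, 89 nM, is far lower, and the gap is well beyond the scatter.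

The next compound, compound 4, `CC(C)CNC(=O)n1c(=O)oc2cc(C3CCN(C)CC3)ccc21`, differs from compound 3 by isobutyl in place of sec-butyl on an amide-type nitrogen. Among the measured compounds shown here, the only measured step that bears on this kind of change is the swap from compound 2 to compound 3, which also altered the group on the amide-type nitrogen and stayed within the scatter. For the measured compounds named here, nothing measured so far shows that rearranging a four-carbon chain at this position moves the number by more than the scatter. The step from compound 3 to compound 4 is therefore expected to be small, a 1.2-fold lower number from compound 3 to compound 4 (0.07 log units; within the scatter). For compound 4 in this assay the estimate is 1800 nM, with a range from 700 nM to 5000 nM.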

Compound 4, half-maximal inhibitory concentration: 166 nM
Compound 4: middle estimate off by 11-fold (1.04 log units), on the high side; the whole stated range lies above it.
By their numbers in this assay, from the lowest: compounds 1 and 4 (each within the scatter of the next); then compounds 2 and 3 (each within the scatter of the next).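

In this assay the two side chains have the same atoms, joined differently, yet isobutyl in place of sec-butyl on the amide-type nitrogen gives a 13-fold lower number from compound 3 to compound 4 (1.10 log units; beyond the scatter) and so shows that this position responds to how the four carbons are joined, not only to how many there are. The earlier step, a 2.0-fold higher number from compound 2 to compound 3 (0.30 log units; within the scatter), could not separate sec-butyl from 2-ethoxyethyl, whereas isopropyl in place of ethoxymethyl on the saturated chain carbon bound to the amide-type nitrogen gives a 6.3-fold lower number from compound 2 to compound 4 (0.80 log units; beyond the scatter) and so sets isobutyl apart from both of those side chains. Nothing available here explains why this rearrangement of the chain matters so much.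

The compounds shown leave open whether a straight n-butyl chain, a tert-butyl group or a longer isopentyl chain on this nitrogen would give a lower or a higher number than isobutyl does. They also leave open whether the difference between isobutyl and sec-butyl would be as large on the core of compound 1, or with an amine at the end of the chain.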